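This account rests on a few compounds, and the source may have more. Where it says the series, first, only, none or still open, it means among the compounds named here.

Measured compounds:
compound 1 `O=c1cc(CSC(=S)N2CCCC2)oc2ccccc12`, in a functional assay on SW480 cells (Homo sapiens) for antiproliferative activity, read by MTT assay, with a stated time of 72 h (on this read-out higher numbers stand for weaker inhibition and lower numbers for stronger inhibition), compound 1 gives 23400 nM
compound 2 `O=c1cc(CSC(=S)N2CCCCC2)oc2ccccc12`, in this assay compound 2 gives 13700 nM

For the measured compounds named here, compound 2 stands at the lowest of the two numbers in this assay, and its only neighbour is compound 1. Going by the values given here, the single measured step, a 1.7-fold lower number from compound 1 to compound 2 (0.23 log units; within the scatter), lies within the scatter, so no order between compound 1 and compound 2 is claimed.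

Compound 3 `O=c1c(Cl)c(CSC(=S)N2CCCCC2)oc2ccccc12` differs from compound 2 by chloro in place of hydrogen on an aromatic carbon. Among the compounds with values here, no measured step bears on this change: the one step available, a 1.7-fold lower number from compound 1 to compound 2 (0.23 log units; within the scatter), alters only the ring on the thiocarbonyl carbon and leaves the shared core untouched. Nothing in the series therefore anchors the direction or size of the move, and the working expectation is for no step beyond the scatter, with the range held wide to cover either direction.

Compound 3 is expected to give 10000 nM in this assay, between 3000 nM and 35000 nM. This estimate means a step of a 1.4-fold lower number from compound 2 to compound 3 (0.14 log units; within the scatter).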

Compound 3, half-maximal inhibitory concentration: 690 nM
The estimate for compound 3 lay 14-fold (1.16 log units) above the measured number; measured number outside the range, below it.
By their numbers in this assay, from the lowest: compound 3; then compounds 2 and 1 (each within the scatter of the next).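

In this assay, for the compounds shown here, chloro in place of hydrogen gives a 20-fold lower number from compound 2 to compound 3 (1.30 log units; beyond the scatter), the first step beyond the scatter, whereas the change of ring on the thiocarbonyl carbon gave only a 1.7-fold lower number from compound 1 to compound 2 (0.23 log units; within the scatter). The position, on an aromatic carbon two atoms from the ring oxygen, thus responds strongly to a change of a single heavy atom on the shared core. No measured evidence accounts for this step.

From the compounds shown here alone, whether the step is specific to chlorine stays open: fluoro, bromo, methyl or methoxy at this position would test that, and an amine or a carboxylic acid would widen the comparison. Also open, going by these compounds, is whether chloro gives a step of similar size when the pyrrolidin-1-yl ring of compound 1 stands on the thiocarbonyl carbon.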